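The compounds below may be only part of what the source reports. "The series", "measured", "known", "first", "only" and "open" are said of these compounds alone.

Working notes on the series. Compound 1 `Cc1cc(-c2nc3sc(C)cn3c2/C=N/NC(=N)N)c(C)s1` and compound 2 `Cc1cn2c(/C=N/NC(=N)N)c(-c3cccs3)nc2s1` share one core; compound 3 `Cc1cc(-c2nc3n(c2/C=N/NC(=N)N)CCS3)c(C)s1` and the unmeasured compound 4 `N=C(N)N/N=C/c1c(-c2cccs2)nc2n1CCS2` share another. The difference between the two cores is not broken down here. In a functional assay on cells (Cancer cell lines, Homo sapiens) for inhibition (on this read-out higher numbers stand for weaker inhibition of growth and lower numbers for stronger inhibition of growth), compound 1 gives 9770 nM, and compound 2 gives 7760 nM. In this assay compound 3 gives 17000 nM; its gap to compound 1 lies within the scatter, its gap to compound 2 beyond it.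

Among the measured compounds shown here, the one measured instance of the change of interest is thiophen-2-yl in place of 2,5-dimethylthiophen-3-yl on an aromatic carbon, which produced a 1.3-fold lower number from compound 1 to compound 2 (0.10 log units; within the scatter). Compound 4 carries the same kind of change on the core of compound 3: thiophen-2-yl in place of 2,5-dimethylthiophen-3-yl on an aromatic carbon. The surroundings are not identical: in compound 4 the carbon also stands two ring bonds from two ring atoms that each bear a fused ring. For the measured compounds named here, a step of similar size is expected from compound 3 to compound 4, a 1.3-fold lower number from compound 3 to compound 4 (0.12 log units; within the scatter), and this rests on the single earlier step of a 1.3-fold lower number from compound 1 to compound 2 (0.10 log units; within the scatter) being within the scatter. Compound 4 is therefore estimated at about 13000 nM in this assay, with a range from 6000 nM to 30000 nM.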

Compound 4, concentration for 50% growth inhibition: 28800 nM
For compound 4 the middle estimate is 2.2-fold (0.35 log units) below the measured one, and the stated range covers the measured number.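

In this assay, thiophen-2-yl in place of 2,5-dimethylthiophen-3-yl gives a 1.7-fold higher number from compound 3 to compound 4 (0.23 log units; within the scatter), so on this second core the step again stays within the scatter. On paper the two steps point in opposite directions, but the data do not separate them: the same change on two cores in this assay, a 1.3-fold lower number (0.10 log units; within the scatter) from compound 1 to compound 2 and a 1.7-fold higher number (0.23 log units; within the scatter) from compound 3 to compound 4, 2.1-fold (0.33 log units) apart, within the scatter of two such steps. This shows that, in these two pairs, the change leaves the read-out within the scatter on either core; it does not show that the change has a real effect of either sign or that the two cores respond differently, and two pairs set no rule for any further core in the series.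

Only these two groups appear on this aromatic carbon among the compounds shown, so it stays open whether a phenyl ring, an amine or a carboxylic acid there would move the number beyond the scatter. Also open, on these data alone, is whether the same change would hold on any core other than these two.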